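The compounds below may be only part of what the source reports. "The series", "measured", "known", "first", "only" and "open" are said of these compounds alone.

Measured compounds, with their concentration for total growth inhibition in a functional assay on CCRF-CEM cells (Homo sapiens) for cytotoxicity, read by MTT assay, with a stated time of 72 h; a higher number here means a weaker inhibitor of growth, a lower number a stronger inhibitor of growth:
Compound 1 `CCCOC(=O)Nc1ccc([Se]C#N)cc1` gives 38400 nM.
Compound 2 `CCCCOC(=O)Nc1ccc([Se]C#N)cc1` gives 27900 nM.
Compound 3 `CCCCCCOC(=O)Nc1ccc([Se]C#N)cc1` gives 46200 nM.

Compound 3 shows the highest of the three numbers, yet every gap between it and the others lies within the scatter: the step of a 1.2-fold higher number from compound 1 to compound 3 (0.08 log units; within the scatter) and the step of a 1.7-fold higher number from compound 2 to compound 3 (0.22 log units; within the scatter) are both small, as is the step of a 1.4-fold lower number from compound 1 to compound 2 (0.14 log units; within the scatter). No ordering among the three compounds can therefore be read from this assay.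

Compound 4 `N#C[Se]c1ccc(NC(=O)Oc2ccccc2)cc1` differs from compound 3 in one place: phenyl in place of hexyl on an oxygen next to a carbonyl group. Every measured step concerns the length of a saturated chain on that oxygen, and none of them moved the number beyond the scatter. For the measured compounds named here, none of them exchanges a chain for an aromatic ring, so no measured step bears directly on this change. On what is shown, the step of a 1.2-fold lower number from compound 3 to compound 4 (0.06 log units; within the scatter) is expected to stay within the scatter, with a wide range to reflect the untested nature of the change. Compound 4 is accordingly estimated at 40000 nM in this assay, between 14000 nM and 115000 nM.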

Compound 4, concentration for total growth inhibition: 48000 nM
The estimate for compound 4 lay 1.2-fold (0.08 log units) below the measured number; low and high end bracket the measured number.
By their numbers in this assay, from the lowest: compounds 2, 1, 3 and 4 (each within the scatter of the next).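

In this assay, for the compounds shown here, phenyl in place of a saturated chain on an oxygen next to a carbonyl group is now seen for the first time, and it stays within the scatter against hexyl (a 1.0-fold higher number from compound 3 to compound 4 (0.02 log units; within the scatter)), butyl (a 1.7-fold higher number from compound 2 to compound 4 (0.24 log units; within the scatter)) and propyl (a 1.3-fold higher number from compound 1 to compound 4 (0.10 log units; within the scatter)). The earlier compounds shown here showed this only for changes in chain length, whereas here one six-membered aromatic ring of carbon only takes the place of a chain with no change in the number beyond the scatter, so the four compounds cannot be ordered. Nothing on hand accounts for this result.

From the compounds shown here alone, whether a benzyl group, a chlorophenyl group or a longer chain such as decyl on that oxygen would move the number beyond the scatter remains open. Every step shown concerns that oxygen's group alone, so the effect of any change to the shared core is also unknown.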